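Compound 3 and a chloro for methyl swap

A few compounds are considered here, and "the series" means these few. Any claim that something is new, unique, unknown or untested is made for them only; others in the source may bear on it.

Compound 1 `Cc1ccc(-c2cc(N)n(-c3ccc(Br)cc3)n2)cc1` gives 80200 nM
Compound 2 `CN(C)/C=N/c1c(C=O)c(-c2ccccc2)nn1-c1ccccc1` gives 9300 nM
Compound 3 `Cc1ccc(-c2nn(-c3cccc(Cl)c3)c(/N=C/N(C)C)c2C=O)cc1` gives 7200 nM

In a functional assay on NPC-TW01 cells (Homo sapiens) for inhibition, read by MTT assay, with a stated time of 72 h (on this read-out lower numbers stand for stronger inhibition of growth and higher numbers for weaker inhibition of growth), compound 3 (7200 nM) lies within the scatter of compound 2, and together they sit at the low end of the numbers, while compound 1 lies beyond the scatter above compound 3. Compound 4 `CN(C)/C=N/c1c(C=O)c(-c2ccc(Cl)cc2)nn1-c1cccc(Cl)c1` has chloro in place of methyl on an aromatic carbon, para to a large group, so 4-methylphenyl becomes 4-chlorophenyl. Among the measured compounds shown here, no measured pair shows this change, so the expectation rests on compound 3 (7200 nM) alone. In this assay no change beyond the scatter is expected, only an estimated 1.1-fold lower number from compound 3 to compound 4 (0.04 log units; within the scatter) with no firm direction. Compound 4 is estimated at 6500 nM (expected range 2800 nM to 15000 nM).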

Compound 4, concentration for 50% growth inhibition: 7400 nM
The estimate for compound 4 lay 1.1-fold (0.06 log units) below the measured number; the measured number falls inside the stated range.
By their numbers in this assay, from the lowest: compounds 3, 4 and 2 (each within the scatter of the next); then compound 1.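

In this assay, among the compounds shown here, the swap of 4-methylphenyl for 4-chlorophenyl gives a 1.0-fold higher number from compound 3 to compound 4 (0.01 log units; within the scatter) and is the first step that changes only one place. On this aromatic carbon, para to a large group, methyl and chloro therefore cannot be told apart in growth inhibition. Nothing at hand accounts for this result. From the compounds shown here alone, whether an amine, a carboxylic acid or a longer chain in this place would also leave the number unmoved remains open. So does whether the same swap would read alike on a different core.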